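This account rests on a few compounds, and the source may have more. Where it says the series, first, only, none or still open, it means among the compounds named here.

Among the measured compounds shown here, in a functional assay on MCF7 cells (Homo sapiens) for cytotoxicity, read by MTT assay, with a stated time of 72 h (on this read-out lower numbers stand for stronger inhibition and higher numbers for weaker inhibition), compound 2 `O=C(CSC(=S)N[C@H]1CCOC1=O)Nc1ccc(C(=O)/C=C/c2ccc(F)cc2)cc1` gives 83700 nM, the only number among the values shown. For compound 1 `CC(=O)c1ccc(NC(=O)CSC(=S)N[C@H]2CCOC2=O)cc1` this assay reported only a limit, (the limit of > 128000 nM in this assay, at which 1 of the 2 values shown sits), and so compound 1 gives > 128000 nM as a limit rather than a number. For the measured compounds named here, the single measured step, an at least 1.5-fold lower number from compound 1 to compound 2 (0.18 log units; that floor lies within the scatter), concerns a change elsewhere in the molecule than the one now at hand. Compound 3 `O=C(CSC(=S)N[C@H]1CCOC1=O)Nc1ccc(C(=O)/C=C/c2ccccc2Cl)cc1` differs from compound 2 by 2-chlorophenyl in place of 4-fluorophenyl on a double-bonded chain carbon bound to a double-bonded chain carbon. Neither the 4-fluorophenyl group nor the 2-chlorophenyl group appears in any measured step, so the data give no ground to expect a move in either direction beyond the scatter. The estimate for compound 3 in this assay is therefore 84000 nM, with a range from 30000 nM to 240000 nM. The step of a 1.0-fold higher number from compound 2 to compound 3 (0.00 log units; within the scatter) that this estimate means is expected to stay within the scatter.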

Compound 3, half-maximal inhibitory concentration: 5570 nM
Beside the measured number, compound 3's estimate is 15-fold (1.18 log units) above it; the whole stated range lies above it.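

Among the compounds shown here, the aryl group on a double-bonded chain carbon bound to a double-bonded chain carbon clearly matters in this assay: 2-chlorophenyl in place of 4-fluorophenyl gives a 15-fold lower number from compound 2 to compound 3 (1.18 log units; beyond the scatter), while the only earlier step, an at least 1.5-fold lower number from compound 1 to compound 2 (0.18 log units; that floor lies within the scatter), could not be told apart from the scatter. Replacing methyl on a carbonyl carbon with 2-(2-chlorophenyl)ethenyl now gives a change clearly beyond the scatter, an at least 22-fold lower number from compound 1 to compound 3 (1.36 log units; beyond the scatter). Compound 1 has only a limit and not a number, so that step is a floor: the limit of > 128000 nM in this assay, at which 1 of the 3 values shown sits.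

Nothing shown explains the change or separates the effect of the chlorine from that of its place on the ring. From the compounds shown here alone, it also remains open how a phenyl ring carrying a methoxy group or an amine would behave here.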